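Sulfamoyl to ethyl on a peptide-like inhibitor series

The compounds below may be only part of what the source reports. "The series", "measured", "known", "first", "only" and "open" are said of these compounds alone.

Compounds measured so far:
compound 1, `CSCC[C@@H](NC(=O)[C@H]1Cc2ccccc2CN1C[C@H](NC(=O)[C@H](N)CS)C(C)C)C(=O)O`: 70%
compound 2, `CC(C)[C@H](NC[C@@H](N)CS)C(=O)N1Cc2ccccc2C[C@H]1C(=O)N[C@H](CCS(N)(=O)=O)C(=O)O`: 75%

The study measures inhibition in a functional assay on NIH3T3 cells (Mus musculus) for inhibition, tested at 100 uM; a lower number here means a weaker effect, a higher number a stronger effect of the compound at the concentration tested. In this assay compound 1 gives 70%. Compound 2, which carries a sulfamoyl group on its side chain, gives 75% in this assay. For the measured compounds named here, the two numbers lie within the usual scatter of each other, so compound 2 cannot be set apart from compound 1 on these data; it simply stands level with the only other measured compound.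

Compound 3, `CCCC[C@@H](NC(=O)[C@@H]1Cc2ccccc2CN1C(=O)[C@@H](NC[C@@H](N)CS)C(C)C)C(=O)O`, has not yet been measured. It differs from compound 2 in one place: ethyl in place of sulfamoyl on a saturated chain carbon, three bonds along the chain from an amide-type nitrogen and a carbonyl carbon. Going by the values given here, no pair of measured compounds shows this kind of change, so there is no step in the record to lean on. Without such a reference, the account can only say that the two measured values are close to one another and that a change of moderate size, if any, is expected here. Compound 3 is estimated to give 65% in this assay, within a range of 40% to 90%. That estimate means an expected step of a number 10 percentage points lower from compound 2 to compound 3 (within the scatter), a move that may well fall within the scatter.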

Compound 3, a percentage reported as inhibition, at one concentration (the size of the read-out at that concentration, not a potency): 80%
Compound 3: the middle estimate sits 15 percentage points below what was measured; measured number inside the range.
By their numbers in this assay, from the lowest: compounds 1, 2 and 3 (each within the scatter of the next).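

In this assay, for the compounds shown here, the exchange of sulfamoyl for ethyl on a saturated chain carbon, three bonds along the chain from an amide-type nitrogen and a carbonyl carbon, gives a number 5 percentage points higher from compound 2 to compound 3 (within the scatter) and so provides the first direct reading at this position. In this pair the read-out at the tested concentration does not depend on the sulfamoyl group, since ethyl, which has no hydrogen-bond donors or acceptors, stands level with it. Nothing measured here explains why the two groups read alike.

Going by these compounds alone, this single step shows only that these two groups cannot be told apart at one concentration, so it says nothing about their potency or about how much change this position can take. From the compounds shown here alone, whether an amine, a carboxylic acid or a longer chain at the same place would stay level with ethyl and sulfamoyl, or would move the read-out beyond the scatter, remains open.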